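Compound 3 to compound 4: a hydroxyphenyl swap

This account rests on a few compounds, and the source may have more. Where it says the series, first, only, none or still open, it means among the compounds named here.

In a functional assay, with a stated time of 30 min (on this read-out higher numbers stand for weaker inhibition and lower numbers for stronger inhibition), compound 1 `O=C(/C=C/c1ccc(O)c(O)c1)CC(=O)/C=C/c1cccc(O)c1O` gives 19000 nM and compound 2 `O=C(/C=C/c1ccccc1O)CC(=O)/C=C/c1cccc(O)c1O` gives 23000 nM while compound 3 `O=C(/C=C/c1cccc(O)c1)CC(=O)/C=C/c1cccc(O)c1O` gives 29000 nM on the shared core. Its number stands level with the other two, as a 1.3-fold higher number from compound 2 to compound 3 (0.10 log units; within the scatter) and a 1.5-fold higher number from compound 1 to compound 3 (0.18 log units; within the scatter) show.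

Compound 4 `O=C(/C=C/c1ccc(O)cc1)CC(=O)/C=C/c1cccc(O)c1O` is not yet measured. The change from compound 3 is 4-hydroxyphenyl in place of 3-hydroxyphenyl on a double-bonded chain carbon bound to a double-bonded chain carbon with 4-hydroxyphenyl in place of 3-hydroxyphenyl on a double-bonded chain carbon bound to a double-bonded chain carbon.

Changes at this same place gave a 1.2-fold higher number from compound 1 to compound 2 (0.08 log units; within the scatter) as well as the two steps already noted, all within the scatter. No step beyond the scatter is therefore expected in this assay for this change, in either direction. The expected step is a 1.2-fold lower number from compound 3 to compound 4 (0.08 log units; within the scatter) on this estimate. For compound 4 the estimated value is 24000 nM with an expected range from 12000 nM to 45000 nM on these few data.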

Compound 4, half-maximal inhibitory concentration: 27000 nM
Beside the measured number, compound 4's estimate is 1.1-fold (0.05 log units) below it; the range from low to high includes it.
By their numbers in this assay, from the lowest: compounds 1, 2, 4 and 3 (each within the scatter of the next).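

In this assay, 4-hydroxyphenyl in place of 3-hydroxyphenyl gives a 1.1-fold lower number from compound 3 to compound 4 (0.03 log units; within the scatter), and 4-hydroxyphenyl in place of 2-hydroxyphenyl gives a 1.2-fold higher number from compound 2 to compound 4 (0.07 log units; within the scatter), so all three placements of the single hydroxy on this ring now read level. The series also shows no step beyond the scatter for the single-hydroxy 4-hydroxyphenyl group against the 3,4-dihydroxyphenyl group, with a 1.4-fold higher number from compound 1 to compound 4 (0.15 log units; within the scatter). No supporting data bear on why the hydroxy placement leaves the number level.

Every compound shown keeps at least one hydroxy on this ring, so it remains open whether an amine or a carboxylic acid there would give a step beyond the scatter. The other end of the shared core is also the same throughout, so the effect of a change there is open too.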